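Chloro to methyl on the weakest indole sulfonamide

The compounds below may be only part of what the source reports. "The series", "measured", "known", "first", "only" and "open" are said of these compounds alone.

Measured compounds:
compound 1 `Cc1noc(C)c1CN1C(c2c(C)n(CC(=O)O)c3ccc(Cl)cc23)c2ccccc2S1(=O)=O` — 8 nM
compound 2 `Cc1c(C2NS(=O)(=O)c3ccccc32)c2cc(Cl)ccc2n1CC(=O)O` — 690 nM
compound 3 `Cc1noc(C)c1CN1C(c2cn(CC(=O)O)c3ccccc23)c2ccccc2S1(=O)=O` — 18 nM

In an assay on cells for binding affinity to prostaglandin D2 receptor 2 (Homo sapiens), read by radioligand binding (on this read-out lower numbers stand for stronger inhibition and higher numbers for weaker inhibition), compound 2 gives the highest of the three numbers, 690 nM; the nearest is compound 3 with 18 nM, the furthest compound 1 with 8 nM. Among the measured compounds shown here, the only single-point step measured, an 86-fold higher number from compound 1 to compound 2 (1.94 log units; beyond the scatter), concerns the sulfonamide nitrogen, not the aromatic ring. Compound 4 `Cc1ccc2c(c1)c(C1NS(=O)(=O)c3ccccc31)c(C)n2CC(=O)O` differs from compound 2 by methyl in place of chloro on an aromatic carbon. For the measured compounds named here, no measured pair isolates that change, so it carries no direct precedent. A small step is therefore expected, within or near the scatter, and compound 4 is estimated at 900 nM (range 300 nM to 2700 nM), a step of a 1.3-fold higher number from compound 2 to compound 4 (0.12 log units; within the scatter).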

Compound 4, inhibition constant: 1500 nM
The estimate for compound 4 lay 1.7-fold (0.22 log units) below the measured number; the range from low to high includes it.
By their numbers in this assay, from the lowest: compound 1; then compound 3; then compound 2; then compound 4.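

In this assay this aromatic carbon now has its first measured pair, and a 2.2-fold higher number from compound 2 to compound 4 (0.34 log units; beyond the scatter) shows that replacing chloro with methyl has an effect beyond the scatter. That step is still much smaller than an 86-fold higher number from compound 1 to compound 2 (1.94 log units; beyond the scatter) on the sulfonamide nitrogen. Nothing available gives a reason for the change at this carbon.

Going by these compounds, whether the same change would matter with (3,5-dimethyl-1,2-oxazol-4-yl)methyl on the sulfonamide nitrogen remains open. So does how fluoro, methoxy or nitrile would compare at this aromatic carbon.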